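Swapping methylamino for methoxy on a shared nucleoside core

This account rests on a few compounds, and the source may have more. Where it says the series, first, only, none or still open, it means among the compounds named here.

Compound 1 `COc1ncnc2c1c(-c1ccsc1)cn2[C@@H]1O[C@H](CO)[C@@H](O)[C@H]1O` gives 7640 nM in a functional assay on CEM-DNR-bulk cells (Homo sapiens), read by MTT assay, with a stated time of 72 h; on this read-out lower numbers stand for stronger inhibition and higher numbers for weaker inhibition.
Compound 2 `COc1ncnc2c1c(-c1ccoc1)cn2[C@@H]1O[C@H](CO)[C@@H](O)[C@H]1O` gives > 20000 nM in this assay, which is a limit of the assay and not a number.
Compound 3 `C#Cc1cn([C@@H]2O[C@H](CO)[C@@H](O)[C@H]2O)c2ncnc(NC)c12` gives 18500 nM in this assay.

Among the two numbers given, compound 3 holds the highest; the nearest is compound 1, whose number is lower by more than the usual scatter. For the measured compounds named here, the only step measured between two compounds that differ in one place is an at least 2.6-fold higher number from compound 1 to compound 2 (0.41 log units; beyond the scatter), and it concerns the five-membered ring on the core, not the group on the six-membered ring.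

Compound 4 `C#Cc1cn([C@@H]2O[C@H](CO)[C@@H](O)[C@H]2O)c2ncnc(OC)c12` has not yet been measured. It differs from compound 3 as follows: methoxy in place of methylamino on an aromatic carbon. Going by the values given here, no measured step covers this exchange, since compounds 1 and 2 both already carry methoxy and differ elsewhere. The step is therefore expected to stay within the scatter, a 1.2-fold lower number from compound 3 to compound 4 (0.09 log units; within the scatter), with no firm direction. On that basis compound 4 is estimated at 15000 nM, ranging from 5000 nM to 40000 nM. Given (the limit of > 20000 nM in this assay, at which 1 of the 3 values shown sits), there is a real chance that compound 4 returns only a limit rather than a number.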

Compound 4, half-maximal inhibitory concentration: 3490 nM
Estimate against measurement, compound 4: 4.3-fold (0.63 log units) above; measured number below the stated range.
By their numbers in this assay, from the lowest: compound 4; then compound 1; then compound 3. At a limit, above all of these: compound 2.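

In this assay, for the compounds shown here, methoxy in place of methylamino on the aromatic carbon next to the ring nitrogen gives a 5.3-fold lower number from compound 3 to compound 4 (0.72 log units; beyond the scatter) and so shows, for the first time in this set, that the group at this position matters: methylamino carries 1 hydrogen-bond donor and methoxy carries 0 hydrogen-bond donors, while both have 2 heavy atoms. With methoxy held in place, ethynyl in place of thiophen-3-yl gives a 2.2-fold lower number from compound 1 to compound 4 (0.34 log units; beyond the scatter) while ethynyl in place of furan-3-yl gives an at least 5.7-fold lower number from compound 2 to compound 4 (0.75 log units; beyond the scatter) and compound 4 therefore holds the lowest number of the four compounds. For compound 2 the reading of > 20000 nM is a limit of the assay and not a number.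

Still open, going by these compounds, is whether methoxy keeps this advantage over methylamino when thiophen-3-yl or furan-3-yl replaces ethynyl, and what an ethoxy or dimethylamino group on the same aromatic carbon would give. Nothing shown here explains why this exchange lowers the number.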